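The source may hold more compounds than are shown below. What is called first, only, known or untested is meant among the compounds shown, and "the series" means these compounds.

Compound 1 `COc1cc(/C=N/Nc2nc(-c3ccc(Br)cc3)cs2)cc(Br)c1OC` was tested in a functional assay on Caco-2 cells (Homo sapiens) for inhibition, read by MTT assay, with a stated time of 48 h (on this read-out lower numbers stand for stronger inhibition and higher numbers for weaker inhibition), where compound 1 gives 36200 nM. Among the two compounds with numbers, compound 1 has the highest; the other, compound 2 `COc1cc(/C=N/Nc2nc(-c3ccc(F)c(F)c3)cs2)cc(Br)c1OC`, gives 21200 nM in this assay. Among the compounds with values here, the one measured step, a 1.7-fold lower number from compound 1 to compound 2 (0.23 log units; within the scatter), came from putting 3,4-difluorophenyl in place of 4-bromophenyl on an aromatic carbon. The unmeasured compound 3 `COc1cc(/C=N/Nc2nc(-c3ccc(C(F)(F)F)cc3)cs2)cc(Br)c1OC` differs from compound 1 in a single place: trifluoromethyl in place of bromo on an aromatic carbon. Within the data shown here, the only measured step that bears on this change is a 1.7-fold lower number from compound 1 to compound 2 (0.23 log units; within the scatter), which alters the same ring and stayed within the scatter. On that basis a step of no size beyond the scatter is expected in this assay, with no clear direction. Compound 3 is therefore estimated to give 30000 nM, with a range from 10000 nM to 90000 nM. The step this estimate means is a 1.2-fold lower number from compound 1 to compound 3 (0.08 log units; within the scatter), which is expected to be small.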

Compound 3, half-maximal inhibitory concentration: 65900 nM
Beside the measured number, compound 3's estimate is 2.2-fold (0.34 log units) below it; the measured number falls inside the stated range.
By their numbers in this assay, from the lowest: compounds 2, 1 and 3 (each within the scatter of the next, the first and the last beyond it).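

In this assay, putting trifluoromethyl in place of bromo gives a 1.8-fold higher number from compound 1 to compound 3 (0.26 log units; within the scatter) at this place on the six-membered aromatic ring of carbon only, para to a large group. Four heavy atoms thus replace a single bromine here without moving the number beyond the usual scatter, and neither group has a hydrogen-bond donor or acceptor. No measurement is available that could explain this small step.

From the compounds shown here alone, whether a group of another kind at this place, such as an amine or a carboxylic acid, would give a step beyond the scatter remains open. Going by these compounds, compound 1 and compound 3 also share the rest of their structure, so it is equally open whether this swap would give a similar step with the core of compound 1 changed elsewhere.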